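The compounds below may be only part of what the source reports. "The series", "measured", "known", "first", "only" and "open" are said of these compounds alone.

Of the compounds shown here, three have so far been measured in a functional assay on LNCaP cells (Homo sapiens) for antiproliferative activity, read by propidium iodide staining, with a stated time of 96 h; a lower number here means a stronger inhibitor, a higher number a weaker inhibitor. Compound 1, `CC(O)(CSc1ccc(S(F)(F)(F)(F)F)cc1)C(=O)Nc1ccc(C#N)c(C(F)(F)F)c1`, gives 16900 nM in this assay. Compound 2, `CC(O)(CSc1ccc(S(F)(F)(F)(F)F)cc1)C(=O)Nc1ccc([N+](=O)[O-])c(C(F)(F)F)c1`, differs from compound 1 by nitro in place of cyano on an aromatic carbon; in this assay compound 2 gives 8700 nM, and that change made a 1.9-fold lower number from compound 1 to compound 2 (0.29 log units; within the scatter). Compound 3, `CC(O)(COc1ccc(S(F)(F)(F)(F)F)cc1)C(=O)Nc1ccc(C#N)c(C(F)(F)F)c1`, gives 11500 nM in this assay; how its core differs from the core of compound 1 is not broken down here. Compound 4, `CC(O)(COc1ccc(S(F)(F)(F)(F)F)cc1)C(=O)Nc1ccc([N+](=O)[O-])c(C(F)(F)F)c1`, has not yet been measured. For the measured compounds named here, it differs from compound 3 by nitro in place of cyano on an aromatic carbon, the same change as the one between compound 1 and compound 2, at a place described in the same words. Because the earlier step was a 1.9-fold lower number from compound 1 to compound 2 (0.29 log units; within the scatter), the same change is expected to make a 1.8-fold lower number from compound 3 to compound 4 (0.25 log units; within the scatter). Compound 4 is therefore estimated at 6500 nM in this assay, with a likely range from 3000 nM to 14000 nM.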

Compound 4, half-maximal inhibitory concentration: 100000 nM
Estimate against measurement, compound 4: 15-fold (1.19 log units) below; measured number above the stated range.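

In this assay, nitro in place of cyano on an aromatic carbon made an 8.7-fold higher number from compound 3 to compound 4 (0.94 log units; beyond the scatter), which does not repeat the step seen on the core of compound 1. The two steps differ, so the change did not carry over from one core to the other: the same change on two cores in this assay, a 1.9-fold lower number (0.29 log units; within the scatter) from compound 1 to compound 2 and an 8.7-fold higher number (0.94 log units; beyond the scatter) from compound 3 to compound 4, 17-fold (1.23 log units) apart, beyond the scatter of two such steps. For the compounds shown here, this shows that, within these four compounds, the step measured on one core was no guide to the step on the other, but it rests on a single pair of steps and does not show what in the cores sets them apart.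

The compounds shown leave open how the same change would behave with a sulfone or an amine linking the aromatic ring in place of the sulfur or oxygen. They also leave open whether a carboxylic acid in place of cyano or nitro would follow either step.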